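Aryl substituent change on the benzylamine arm

The source may report more compounds than this note shows. Statements on the series, on what has been measured and on what is new or still open speak of the compounds shown alone.

Measured compounds:
compound 1, `Nc1nc(NCc2ccc(Cl)cc2)nc(-c2ccccc2CO)n1`; in a functional assay on cells for positive allosteric modulation of G-protein coupled receptor 68 (Homo sapiens), read by a luciferase reporter and cAMP accumulation, with a stated time of 30 min, at pH 6.8 and pH 8.3, in the presence of a further agent that is not named here (on this read-out higher numbers stand for higher potency (the scale is a negative logarithm) and lower numbers for lower potency), compound 1 gives 5.22
compound 2, `Cc1ccccc1CNc1nc(N)nc(-c2ccccc2CO)n1`; in this assay compound 2 gives 4.7

Compound 1 holds the higher of the two numbers; the move to compound 2 is a number 0.52 log units lower from compound 1 to compound 2 (beyond the scatter), with 2-methylphenyl in place of 4-chlorophenyl on a saturated chain carbon bound to a nitrogen on an aromatic ring. Within the data shown here, that is the only measured step, and it changes both the group and the place on the aryl ring at once.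

Compound 3, `Nc1nc(NCc2ccc(OC3CC3)cc2)nc(-c2ccccc2CO)n1`, is not yet measured. It differs from compound 1 by cyclopropyloxy in place of chloro on an aromatic carbon. Among the measured compounds shown here, no measured step varies this position alone, so the one known step bears on it only loosely: it shows that a change on this aryl ring has so far moved this assay by a modest amount, and no more. The chloro of compound 1 is replaced by a larger group at the same place; the direction of any shift cannot be read from the data.

For the measured compounds named here, the expectation for compound 3 in this assay is therefore a number close to compound 1, with no step clearly beyond the scatter. Compound 3 is expected at 5.2, in the range 4.6 to 5.8. The step thus expected is a number 0.02 log units lower from compound 1 to compound 3 (within the scatter).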

Compound 3, negative logarithm of the antagonist equilibrium constant: 5.07
The estimate for compound 3 lay 0.13 log units above the measured number, within the range that was stated.
By their numbers in this assay, from the lowest: compound 2; then compounds 3 and 1 (each within the scatter of the next).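

In this assay, the place on an aromatic carbon para to a large group accepts cyclopropyloxy in place of chloro with no shift that can be told from the scatter, a number 0.15 log units lower from compound 1 to compound 3 (within the scatter), although the entering group brings a three-membered non-aromatic ring of carbon only and a hydrogen-bond acceptor that chloro lacks. Among these compounds, this is the first measured change confined to this one place, and it sets a limit that the earlier step, a number 0.52 log units lower from compound 1 to compound 2 (beyond the scatter), could not set, since that step altered both the group and its place on the aryl ring. No measurement available here offers an explanation for the similar numbers of compound 1 and compound 3.

As far as these compounds go, both groups at this place carry no net charge, so the response to an amine or a carboxylic acid there remains open, as does the response to a longer alkoxy chain. From the compounds shown here alone, it also remains open whether the step to compound 2 follows from the methyl group itself or from its place on the ring, and a methyl group at the place held by chloro in compound 1 would separate the two.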